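Swapping a Carbonyl Link for a Sulfonyl Link

This account rests on a few compounds, and the source may have more. Where it says the series, first, only, none or still open, it means among the compounds named here.

In an assay on U2OS cells for inhibition of secreted frizzled-related protein 1 (Homo sapiens), read by a luciferase reporter, with a stated time of 18 h (a lower number here means that less compound is needed, a higher number that more compound is needed for the effect), compound 1 `O=C(c1ccccc1)N1CCC(NS(=O)(=O)c2cc(S(=O)(=O)c3ccccc3)ccc2C(F)(F)F)CC1` gives 250 nM, compound 2 `O=C(c1cccnc1)N1CCC(NS(=O)(=O)c2cc(S(=O)(=O)c3ccccc3)ccc2C(F)(F)F)CC1` gives 120 nM and compound 3 `CN(C)c1ccc(C(=O)N2CCC(NS(=O)(=O)c3cc(S(=O)(=O)c4ccccc4)ccc3C(F)(F)F)CC2)cn1` gives 70 nM. Compound 3 has the lowest number of the three: the step of a 3.6-fold lower number from compound 1 to compound 3 (0.55 log units; beyond the scatter) lies beyond the scatter, whereas a 1.7-fold lower number from compound 2 to compound 3 (0.23 log units; within the scatter) stays within the scatter. Compound 4 `N#Cc1cccc(S(=O)(=O)N2CCC(NS(=O)(=O)c3cc(S(=O)(=O)c4ccccc4)ccc3C(F)(F)F)CC2)c1` changes ((3-cyanophenyl)sulfonyl in place of (6-(dimethylamino)pyridin-3-yl)carbonyl on an amine nitrogen in a ring). Among the compounds with values here, none of the measured steps touches this link: a 2.1-fold lower number from compound 1 to compound 2 (0.32 log units; beyond the scatter) and the other two only vary the group on the carbonyl carbon, each by a modest amount. With nothing to anchor the new link, the step of a 2.9-fold higher number from compound 3 to compound 4 (0.46 log units; beyond the scatter) is estimated to be small. Compound 4 is therefore expected to give about 200 nM, between 50 nM and 800 nM.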

Compound 4, half-maximal effective concentration: 170 nM
Estimate against measurement, compound 4: 1.2-fold (0.07 log units) above; measured number inside the range.
By their numbers in this assay, from the lowest: compounds 3, 2, 4 and 1 (each within the scatter of the next, the first and the last beyond it).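

A sulfonyl link on the ring amine nitrogen can stand in for a carbonyl link: in this assay, the (3-cyanophenyl)sulfonyl group gives a 1.4-fold higher number from compound 2 to compound 4 (0.15 log units; within the scatter) and a 1.5-fold lower number from compound 1 to compound 4 (0.17 log units; within the scatter). Only (6-(dimethylamino)pyridin-3-yl)carbonyl remains ahead of it, with a 2.4-fold higher number from compound 3 to compound 4 (0.39 log units; beyond the scatter). No measurement shown explains these steps.

As far as these compounds go, each step changes the link and its aromatic ring together, so their separate shares remain unknown. Open too, from the compounds shown here alone, is how a (6-(dimethylamino)pyridin-3-yl)sulfonyl group, joining the dimethylamino-bearing ring to the new link, would compare.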